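The source may hold more compounds than are shown below. What is called first, only, known or untested is meant among the compounds shown, and "the series" means these compounds.

Compound 1, `Oc1ccc(-c2cc(-c3cccc(O)c3)nc(-c3ccccc3O)c2)cc1`, is the only one of the three measured compounds that returns a definite number in an ADME assay on HEK293 cells (Homo sapiens) for cytotoxicity, read by CCK-8 assay, with a stated time of 4 days; a higher number here means a weaker inhibitor, a lower number a stronger inhibitor; in this assay compound 1 gives 7420 nM. Compound 2, `Oc1ccc(-c2cc(-c3ccccc3O)nc(-c3ccccc3O)c2)cc1`, reaches only a limit of this assay, recorded as > 50000 nM, so no number is known for it. Compound 3, `Oc1cccc(-c2cc(-c3cccc(O)c3)nc(-c3ccccc3O)c2)c1`, likewise sits at a limit of this assay, recorded as > 50000 nM. Both of these steps away from compound 1 are therefore counted against a ceiling, (the limit of > 50000 nM in this assay, at which 2 of the 3 values shown sit).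

Compound 4, `Oc1ccc(-c2cc(-c3ccc(O)cc3)nc(-c3cccc(O)c3)c2)cc1`, has not yet been measured. It differs from compound 1 in a single place: 4-hydroxyphenyl in place of 2-hydroxyphenyl on an aromatic carbon. Among the compounds with values here, two measured steps bear on this change. From compound 1 to compound 2 the result rose to the limit, an at least 6.7-fold higher number from compound 1 to compound 2 (0.82 log units; beyond the scatter), and from compound 1 to compound 3 it rose in the same way, an at least 6.7-fold higher number from compound 1 to compound 3 (0.82 log units; beyond the scatter). Each of these swaps one hydroxyphenyl group for another on the shared core, exactly the kind of change that separates compound 1 from compound 4, and each moved the number well beyond the scatter toward weaker inhibition. A similar upward step is expected here, a 5.4-fold higher number from compound 1 to compound 4 (0.73 log units; beyond the scatter), with a real chance that only a limit is reported. Compound 4 is estimated to give about 40000 nM in this assay, expected to fall between 10000 nM and 120000 nM.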

Compound 4, half-maximal inhibitory concentration: 840 nM
Compound 4: middle estimate off by 48-fold (1.68 log units), on the high side; measured number outside the range, below it.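

On the carbon next to the ring nitrogen, 4-hydroxyphenyl in place of 2-hydroxyphenyl gives an 8.8-fold lower number from compound 1 to compound 4 (0.95 log units; beyond the scatter), so in this assay moving the hydroxyl around a hydroxyphenyl group can also lower the number, not only raise it as the two earlier steps did. The groups that leave and enter have the same atoms and the same counts of hydrogen-bond donors and acceptors, so this step comes from rearranging those atoms alone, and the 2-hydroxyphenyl group of compound 1 is clearly not needed for a definite number in this assay. This is also the only step here with a measured number at both ends, whereas the two earlier steps can be read only against a ceiling: the limit of > 50000 nM in this assay, at which 2 of the 4 values shown sit.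

The compounds shown do not tell how 3-hydroxyphenyl would behave at this same place, so it remains unknown whether the number changes gradually as the hydroxyl moves around the ring. They also leave open whether the hydroxyl itself matters here, since a methoxy group, an amine or a plain phenyl ring at this place would be needed to test that.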